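A few compounds are considered here, and "the series" means these few. Any claim that something is new, unique, unknown or untested is made for them only; others in the source may bear on it.

Working notes on the series. Among the measured compounds shown here, compound 1 `COc1ccc(C(=O)NO)cc1NCc1ccc(OCCCCC(=O)Nc2ccc3c(c2)cc(C)c(=O)n3C)cc1` is the first measured point; in a functional assay on HL-60 cells (Homo sapiens) for antiproliferative activity, tested at 4 uM (a higher number here means a stronger effect of the compound at the concentration tested, a lower number a weaker effect), compound 1 gives 0%. Compound 2 `COc1ccc(C(=O)NO)cc1CS(=O)(=O)Nc1ccc2c(c1)cc(C)c(=O)n2C` is the second; in this assay compound 2 gives 0%, level with compound 1 at the digits shown, with compound 1 as its nearest neighbour and no change beyond the scatter between the two. Both measured values sit at the floor of the read-out at the concentration tested.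

Compound 3 `Cc1cc2cc(NS(=O)(=O)Cc3cccc(C(=O)NO)c3)ccc2n(C)c1=O` is the next point. The change from compound 2 is hydrogen in place of methoxy on an aromatic carbon. For the measured compounds named here, no step between measured compounds is available to size such a change, and the two measured values give no spread to work from. The step is expected to be none beyond the scatter: no change at the digits printed from compound 2 to compound 3 (within the scatter). For compound 3 the estimate in this assay is 0%, with a range from 0% to 15%.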

Compound 3, a percentage reported as inhibition, at one concentration (the size of the read-out at that concentration, not a potency): 0%
Beside the measured number, compound 3's estimate shows no gap at the digits printed; low and high end bracket the measured number.
By their numbers in this assay, from the lowest: compounds 1, 2 and 3 (each within the scatter of the next).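

Among the compounds shown here, the step at this position, on the aromatic carbon para to the hydroxycarbamoyl group, is the first one-place comparison: in this assay, hydrogen in place of methoxy gives no change at the digits printed from compound 2 to compound 3 (within the scatter). Since compound 3 stays at 0%, removing the methoxy brings no measurable gain, but with neither compound showing any inhibition at the concentration tested, the step cannot show what methoxy contributes at this place. No evidence on hand bears on this result.

Going by these compounds, it remains open whether an amine, a chlorine atom or a longer alkoxy chain at this carbon would lift the read-out off the floor. On these data alone, it also remains open whether the two compounds would separate at a higher concentration.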